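Fluoro in place of hydrogen on the phenyl of compound 2

A few compounds are considered here, and "the series" means these few. Any claim that something is new, unique, unknown or untested is made for them only; others in the source may bear on it.

Measured so far in an assay on CHO cells for displacement of a labelled ligand from Substance-P receptor (Homo sapiens); a higher number here means a weaker inhibitor, a lower number a stronger inhibitor:
compound 1, `C[C@@H](O[C@@H]1[C@@H](c2ccccc2)CN(C(=O)OC(C)(C)C)[C@H]1CO)c1cc(C(F)(F)F)cc(C(F)(F)F)c1`, gives 3.6 nM
compound 2, `C[C@@H](O[C@@H]1[C@@H](c2ccccc2)CN2C(=O)OC[C@H]12)c1cc(C(F)(F)F)cc(C(F)(F)F)c1`, gives 1.5 nM
compound 3, `C[C@@H](O[C@H]1CN(C(=O)OC(C)(C)C)[C@@H](CO)[C@@H]1c1ccccc1)c1cc(C(F)(F)F)cc(C(F)(F)F)c1`, gives 0.63 nM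

Compound 2 stands second highest of the three numbers in this assay: compound 3 sits at a lower number than compound 2, and compound 1 at a higher one, both gaps beyond the usual scatter. Those two neighbours differ from compound 2 in more than one place, so no single step can be read from them.

Compound 4, `C[C@@H](O[C@@H]1[C@@H](c2ccc(F)cc2)CN2C(=O)OC[C@H]12)c1cc(C(F)(F)F)cc(C(F)(F)F)c1`, is the as yet unmeasured partner of compound 2. The difference between the two is fluoro in place of hydrogen on an aromatic carbon. It is small in count, a single heavy atom with no donor, no acceptor and no charge, placed on the six-membered aromatic ring para to a large group.

For the measured compounds named here, with no measured pair of this kind to lean on, the expected step from compound 2 to compound 4 is none beyond the scatter, estimated as a 1.2-fold lower number from compound 2 to compound 4 (0.06 log units; within the scatter). Compound 4 is therefore expected to give about 1.3 nM in this assay, within a range from 0.45 nM to 4 nM.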

Compound 4, half-maximal inhibitory concentration: 1 nM
Compound 4: the middle estimate sits 1.3-fold (0.11 log units) above what was measured; the measured number falls inside the stated range.
By their numbers in this assay, from the lowest: compounds 3, 4 and 2 (each within the scatter of the next, the first and the last beyond it); then compound 1.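

In this assay, for the compounds shown here, the change from phenyl to 4-fluorophenyl gives the first step in this set that can be read at a single place, and a 1.5-fold lower number from compound 2 to compound 4 (0.18 log units; within the scatter) is all that it amounts to. Fluoro on this aromatic carbon, para to a large group, therefore leaves compound 4 not distinguishable from compound 2 in this assay, so this position accepts that one heavy atom without a change that can be told from the scatter. Nothing at hand bears on what lies behind this result.

As far as these compounds go, whether a chlorine, a methoxy group or a nitrile at the same carbon would also stay within the scatter remains open. So does whether the same change would read alike on the core of compound 1 or compound 3.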